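Replacing the 2-oxopyrrolidin-1-yl group of compound 2

The source may report more compounds than this note shows. Statements on the series, on what has been measured and on what is new or still open speak of the compounds shown alone.

Measured in a functional assay (aorta) with Rattus norvegicus as the target; on this read-out higher numbers stand for an effect only at larger amounts of compound and lower numbers for an effect already at smaller amounts:

Compound 1 `O=C1CCCN1C1=CC(CF)(CF)Oc2ccc([N+](=O)[O-])cc21` gives 7.76 nM 
Compound 2 `O=C1CCCN1C1=CC(CF)(CF)Oc2ccc(C(F)(F)C(F)(F)F)cc21` gives 1.51 nM 

Compound 2 has the lower of these two numbers, so it shows its effect at the smaller amount. Within the data shown here, the only measured step is a 5.1-fold lower number from compound 1 to compound 2 (0.71 log units; beyond the scatter), beyond the usual scatter, and it came from 1,1,2,2,2-pentafluoroethyl in place of nitro on an aromatic carbon.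

Compound 3 `O=C1CCCCN1C1=CC(CF)(CF)Oc2ccc(C(F)(F)C(F)(F)F)cc21` has not been measured yet. It has 2-oxopiperidin-1-yl in place of 2-oxopyrrolidin-1-yl on a double-bonded ring carbon. The measured step changed a different place, so it gives only a rough sense of how large a single change can be in this assay and no direction for this one. Among the measured compounds shown here, no measured pair tests a change at this carbon. A small step is therefore expected, probably within the scatter, starting from compound 2 at 1.51 nM and with a wide margin. The expected change is a 1.3-fold higher number from compound 2 to compound 3 (0.12 log units; within the scatter). Compound 3 is estimated at 2 nM, with an expected range from 0.6 nM to 7 nM.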

Compound 3, half-maximal effective concentration: 5.62 nM
Compound 3: middle estimate off by 2.8-fold (0.45 log units), on the low side, within the range that was stated.
By their numbers in this assay, from the lowest: compound 2; then compounds 3 and 1 (each within the scatter of the next).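

The carbon that carries this ring is sensitive to ring size. In this assay, enlarging the 2-oxopyrrolidin-1-yl group to 2-oxopiperidin-1-yl gives a 3.7-fold higher number from compound 2 to compound 3 (0.57 log units; beyond the scatter), so a larger amount of compound is needed for the effect after a change of just one ring carbon. Among these compounds, the earlier step showed only that the group on the aromatic carbon matters, whereas this one shows that a second place on the shared core also responds beyond the scatter, and nothing available explains why the six-membered ring reads this way.

With only these two rings at this carbon, the compounds shown leave open how a seven-membered ring of the same kind, an open-chain acetamide or a plain amine would read, and two ring sizes alone do not establish a trend. They also leave open whether the ring change would give a step of similar size and direction with nitro, the group in compound 1, in place of 1,1,2,2,2-pentafluoroethyl on the aromatic carbon.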